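Reversing part of the ring change at the carboxyaryl end

The source may report more compounds than this note shows. Statements on the series, on what has been measured and on what is new or still open speak of the compounds shown alone.

Compound 3 `O=C(O)c1cncc(-c2ccc(N3CCC(Oc4cc(F)ccc4Br)CC3)nn2)n1` gives 772 nM in an assay on isolated protein for inhibition of acyl-CoA desaturase 1 (Rattus norvegicus) (on this read-out higher numbers stand for weaker inhibition and lower numbers for stronger inhibition), the highest of the two numbers shown. Compound 1 `O=C(O)c1cncc(-c2ccc(N3CCC(Oc4cc(F)ccc4Br)CC3)nn2)c1` gives 15 nM. Compound 2 `O=C(O)c1cncc(-c2ccc(N3CCC(Oc4c(F)cc(F)cc4Br)CC3)nn2)c1` gives only a limit, > 20000 nM, as the limit of > 20000 nM in this assay, at which 1 of the 3 values shown sits. The step of a 51-fold higher number from compound 1 to compound 3 (1.71 log units; beyond the scatter) was large, and the step of an at least 1300-fold higher number from compound 1 to compound 2 (3.12 log units; beyond the scatter) was larger still. Compound 4 `O=C(O)c1ccc(-c2ccc(N3CCC(Oc4cc(F)ccc4Br)CC3)nn2)nc1` carries 5-carboxypyridin-2-yl in place of 6-carboxypyrazin-2-yl on an aromatic carbon. This change bears on the step of a 51-fold higher number from compound 1 to compound 3 (1.71 log units; beyond the scatter), since it removes one ring nitrogen while keeping the attachment next to the ring nitrogen and para to a large group. Because the step of a 51-fold higher number from compound 1 to compound 3 (1.71 log units; beyond the scatter) was large, a partial reversal is expected, with a 5.1-fold lower number from compound 3 to compound 4 (0.71 log units; beyond the scatter) toward stronger inhibition. Compound 4 is therefore estimated at 150 nM, in the range 40 nM to 800 nM.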

Compound 4, half-maximal inhibitory concentration: 8 nM
Compound 4: middle estimate off by 19-fold (1.27 log units), on the high side; measured number outside the range, below it.
By their numbers in this assay, from the lowest: compounds 4 and 1 (each within the scatter of the next); then compound 3. At a limit, above all of these: compound 2.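

The 5-carboxypyridin-2-yl group in place of 6-carboxypyrazin-2-yl gives a 97-fold lower number from compound 3 to compound 4 (1.98 log units; beyond the scatter) in this assay, a larger change than the one that separated the first two carboxyaryl groups. Against 5-carboxypyridin-3-yl, the same group gives a 1.9-fold lower number from compound 1 to compound 4 (0.27 log units; within the scatter), so these two carboxypyridinyl groups cannot be told apart here. The attachment next to the ring nitrogen therefore does not by itself go with weak inhibition, whereas the 6-carboxypyrazin-2-yl group does. Nothing shown explains the effect of the second ring nitrogen. On these data alone, whether a primary amide or a tetrazole could replace the carboxylic acid on the 5-carboxypyridin-2-yl group remains open.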